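This account rests on a few compounds, and the source may have more. Where it says the series, first, only, none or still open, it means among the compounds named here.

Measured compounds:
Compound 1, `O=C(O)Cc1sc(C(c2ccc(F)cc2)c2ccc(F)cc2)nc1-c1ccncc1`: 40 nM
Compound 2, `O=C(O)Cc1sc(C(c2ccc(F)cc2)c2ccc(F)cc2)nc1-c1ccnc(F)c1`: 4.7 nM
Compound 3, `O=C(O)Cc1sc(C(c2ccc(F)cc2)c2ccc(F)cc2)nc1-c1cc(F)nc(F)c1`: 110 nM

In an in vitro functional assay on HEK285-7 cells for antagonist activity at prostaglandin D2 receptor 2 (Homo sapiens), read by BRET and beta-arrestin recruitment (a lower number here means a stronger inhibitor, a higher number a weaker inhibitor), compound 3 stands at the highest of the three numbers; its nearest neighbour is compound 1, and the farthest is compound 2, which shows the lowest number of the set. The step from compound 1 to compound 2 was an 8.5-fold lower number from compound 1 to compound 2 (0.93 log units; beyond the scatter), whereas the step from compound 2 to compound 3 was a 23-fold higher number from compound 2 to compound 3 (1.37 log units; beyond the scatter), and that from compound 1 to compound 3 was a 2.8-fold higher number from compound 1 to compound 3 (0.44 log units; beyond the scatter).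

Compound 4, `Cc1cc(-c2nc(C(c3ccc(F)cc3)c3ccc(F)cc3)sc2CC(=O)O)ccn1`, differs from compound 3 by 2-methylpyridin-4-yl in place of 2,6-difluoropyridin-4-yl on an aromatic carbon. This move takes away both fluorines and puts in a single methyl, so the two steps that bear on it are the large rise seen from compound 2 to compound 3 and the modest fall seen from compound 1 to compound 2. For the measured compounds named here, no measured step shows a methyl on this ring, so how far a methyl behaves like the one fluoro of compound 2 remains open. A lower number in this assay is expected, of moderate size. Compound 4 is accordingly estimated at 15 nM, within 3 nM to 70 nM, a step of a 7.3-fold lower number from compound 3 to compound 4 (0.87 log units; beyond the scatter).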

Compound 4, half-maximal inhibitory concentration: 53 nM
Estimate against measurement, compound 4: 3.5-fold (0.55 log units) below, within the range that was stated.
By their numbers in this assay, from the lowest: compound 2; then compounds 1 and 4 (each within the scatter of the next); then compound 3.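

In this assay, a single substituent on this ring does not act the same way whichever group it is: methyl in place of hydrogen gives a 1.3-fold higher number from compound 1 to compound 4 (0.12 log units; within the scatter), which lies within the scatter, while fluoro in place of hydrogen gave an 8.5-fold lower number from compound 1 to compound 2 (0.93 log units; beyond the scatter). For the compounds shown here, the direct exchange of the two groups confirms this, since methyl in place of fluoro gives an 11-fold higher number from compound 2 to compound 4 (1.05 log units; beyond the scatter), so the gain carried by the single fluoro of compound 2 does not carry over to the methyl of compound 4. Going from the 2,6-difluoropyridin-4-yl group to the 2-methylpyridin-4-yl group gives only a 2.1-fold lower number from compound 3 to compound 4 (0.32 log units; beyond the scatter), so removing the second fluoro does not by itself bring the number down to that of compound 2 once a methyl stands in the place of the first.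

From the compounds shown here alone, whether a chloro, methoxy, trifluoromethyl or amine group on this ring would follow the fluoro of compound 2 or the methyl of compound 4 stays open. Nothing given here accounts for the difference between the fluoro and the methyl.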